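Compound 1 to compound 4: one methoxy fewer

The source may hold more compounds than are shown below. What is called first, only, known or untested is meant among the compounds shown, and "the series" means these compounds.

In a functional assay on the whole organism (strain Kunming) with Mus musculus as the target, in the formalin test, with a stated time of 0.5 h (a higher number here means that more compound is needed for the effect, a lower number that less compound is needed), compound 1 `COc1cc(OC)c(OC)cc1/C=C/COC(=O)/C=C/c1ccc(OC)c(OC)c1` gives 93.3 mg/kg. Compound 2 `COc1cc(OC)c(OC)cc1/C=C/COC(=O)/C=C/c1cc(OC)c(OC)c(OC)c1` gives 85.5 mg/kg, and compound 3 `COc1cc(OC)c(OC)cc1/C=C/COC(=O)/C=C/c1cccc(Br)c1` gives 113 mg/kg. Compound 1 cannot be separated from either of the other two, since both of its steps lie within the scatter.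

Compound 4 `COc1ccc(/C=C/C(=O)OC/C=C/c2cc(OC)c(OC)cc2OC)cc1` has not yet been measured. It differs from compound 1 by hydrogen in place of methoxy on an aromatic carbon, ortho to a methoxy group and meta to a large group, so that 3,4-dimethoxyphenyl becomes 4-methoxyphenyl: hydrogen in place of methoxy on an aromatic carbon.

Within the data shown here, two measured steps bear on this change. The closer one is methoxy in place of hydrogen on an aromatic carbon, the same kind of exchange in the opposite sense, and it amounts to a 1.1-fold lower number from compound 1 to compound 2 (0.04 log units; within the scatter). The other replaces the whole 3,4-dimethoxyphenyl group with 3-bromophenyl and amounts to a 1.2-fold higher number from compound 1 to compound 3 (0.08 log units; within the scatter). Neither step leaves the scatter, so no step beyond the scatter is expected in this assay, and the data support no direction. The expected change is a 1.1-fold higher number from compound 1 to compound 4 (0.02 log units; within the scatter). For compound 4 the estimated value is 98 mg/kg, with an expected range of 60 mg/kg to 150 mg/kg.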

Compound 4, dose for half-maximal effect: 122 mg/kg
Compound 4: middle estimate off by 1.2-fold (0.10 log units), on the low side; the range from low to high includes it.
By their numbers in this assay, from the lowest: compounds 2, 1, 3 and 4 (each within the scatter of the next).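

In this assay, the exchange at this aromatic carbon has now been read directly, and hydrogen in place of methoxy gives a 1.3-fold higher number from compound 1 to compound 4 (0.12 log units; within the scatter); together with the opposite kind of exchange elsewhere on the same phenyl group, a 1.1-fold lower number from compound 1 to compound 2 (0.04 log units; within the scatter), this means that neither adding nor removing a methoxy has left the scatter. The comparison of the two substituted phenyl groups also stays inside it, with a 1.1-fold higher number from compound 3 to compound 4 (0.03 log units; within the scatter), so 4-methoxyphenyl cannot be told apart from 3-bromophenyl, and the loss of this methoxy sets no direction for the series. No measurement accompanies these compounds that could explain the size of these steps.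

Going by these compounds, whether an amine, a hydroxyl or a carboxylic acid at this aromatic carbon would give a step beyond the scatter remains open, and so does the effect of an unsubstituted phenyl group in place of 4-methoxyphenyl. On these data alone, it is also open whether any change to the shared core outside this phenyl group would move the number further than these exchanges have.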